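Ethyl to isopropyl on the ring amide nitrogen

The source may report more compounds than this note shows. Statements on the series, on what has been measured and on what is new or still open speak of the compounds shown alone.

Among the measured compounds shown here, compound 2 `CCN1C(=O)c2cc(C)nc(Oc3cccc(NS(=O)(=O)c4ccc(Cl)cc4)c3)c2C1=O` has the lower of the two numbers measured so far: in a functional assay on HEK293 cells for agonist activity at Glucose-dependent insulinotropic receptor (Homo sapiens), read by cAMP accumulation, with a stated time of 30 min (a higher number here means a larger maximal response, a lower number a smaller maximal response), compound 2 gives 120%, while compound 1 `Cc1cc2c(c(Oc3cccc(NS(=O)(=O)c4ccc(Cl)cc4)c3)n1)C(=O)N(C)C2=O` gives 122% in this assay, and the step of a number 2 percentage points lower from compound 1 to compound 2 (within the scatter) lies within the scatter. Compound 3 `Cc1cc2c(c(Oc3cccc(NS(=O)(=O)c4ccc(Cl)cc4)c3)n1)C(=O)N(C(C)C)C2=O` differs from compound 2 by methyl in place of hydrogen on a saturated chain carbon bound to an amide-type nitrogen in a ring and a saturated chain carbon. For the measured compounds named here, the only measured step that bears on it, a number 2 percentage points lower from compound 1 to compound 2 (within the scatter), is the same kind of change one bond further in and was within the scatter, so no step beyond the scatter is expected in this assay. Compound 3 is estimated at 118%, range 105% to 130%, an expected step of a number 2 percentage points lower from compound 2 to compound 3 (within the scatter).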

Compound 3, largest response reached (reported as efficacy), in percent of the reference or control that the assay uses: 99%
Estimate against measurement, compound 3: 19 percentage points above; the measured number lies below the stated range.
By their numbers in this assay, from the lowest: compound 3; then compounds 2 and 1 (each within the scatter of the next).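

Among the compounds shown here, on the ring amide nitrogen, ethyl to isopropyl gives a number 21 percentage points lower from compound 2 to compound 3 (beyond the scatter) in this assay and thus marks the first step beyond the scatter at this position. Isopropyl in place of methyl gives a number 23 percentage points lower from compound 1 to compound 3 (beyond the scatter) in the same read-out, so among these three compounds only the isopropyl compound 3 stands apart, while methyl and ethyl remain within the scatter of each other. Nothing available accounts for this drop.

Open, going by these compounds, is whether a longer chain such as n-propyl, or a cyclopropyl or tert-butyl group, on this nitrogen would match compound 2 or compound 3. Also open, on these data alone, is whether the same change carries over to other sulfonamide aryl groups.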